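A few compounds are considered here, and "the series" means these few. Any claim that something is new, unique, unknown or untested is made for them only; others in the source may bear on it.

Within the data shown here, in a functional assay (ileum) with Cavia porcellus as the target (on this read-out lower numbers stand for lower potency and higher numbers for higher potency (the scale is a negative logarithm)), compound 1 `COC(=O)C1CC2CC1N(C)C2` gives 4.2, the only actual number so far. Compound 2 `COC(=O)[C@@H]1C[C@@H]2C[C@H]1N(C)C2` reads < 4, which is a limit of the assay. Compound 3 `COC(=O)C1CC2CNC1C2` alters the core of compound 1 in one place: hydrogen in place of methyl on an amine nitrogen in a ring. Among the measured compounds shown here, the only measured step, a number at least 0.20 log units lower from compound 1 to compound 2 (that floor lies within the scatter), concerns the fact that one of compounds 1 and 2 is drawn with a defined configuration and the other without, at the place where they differ and not this group, so it sets no size for the change. A step beyond the scatter is therefore not expected, and the estimated step is a slight drop, a number 0.20 log units lower from compound 1 to compound 3 (within the scatter). The expected value for compound 3 is 4, with a range from 3.5 to 4.6.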

Compound 3, negative logarithm of the half-maximal effective concentration: 6.2
Compound 3: the middle estimate sits 2.20 log units below what was measured; the whole stated range lies below it.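

In this assay, an amine nitrogen in a ring proves to be a place where a very small change has a large effect: hydrogen in place of methyl gives a number 2.00 log units higher from compound 1 to compound 3 (beyond the scatter), and compound 3 is clearly the more potent of the pair. The earlier step concerned only drawn configuration, so this is the first size shown for a change at this nitrogen. Nothing shown here accounts for a change of this size.

Going by these compounds, whether ethyl, a longer chain or an acetyl group on this nitrogen would keep the potency of compound 3 remains open. So does the role of configuration in compound 3, which is drawn without one.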